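Replacing a dimethylphenyl amide with a difluorophenyl one

A few compounds are considered here, and "the series" means these few. Any claim that something is new, unique, unknown or untested is made for them only; others in the source may bear on it.

Compound 1 `Cc1ccc(NC(=O)CN2CCN(c3nnc(Cc4ccccc4)c4ccccc34)CC2)c(C)c1` carries a 2,4-dimethylphenyl group on its amide nitrogen. In a functional assay on A549 cells (Homo sapiens) for cytotoxicity, read by MTT assay, with a stated time of 72 h (a lower number here means a stronger inhibitor, a higher number a weaker inhibitor), compound 1 gives "not active" (no number reported), so no single number places it among the measured compounds. Its closest measured relative is compound 3 `Cc1ccc(NC(=O)CN2CCN(c3nnc(Cc4ccncc4)c4ccccc34)CC2)c(C)c1`, which shares the same 2,4-dimethylphenyl amide and gives 45000 nM in this assay. Going by the values given here, compound 2 `O=C(CN1CCN(c2nnc(Cc3ccncc3)c3ccccc23)CC1)Nc1cc(C(F)(F)F)ccc1Cl` gives 1850 nM in this assay, and the one measured step that exchanges the amide aryl group, a 24-fold higher number from compound 2 to compound 3 (1.39 log units; beyond the scatter), shows that this part of the molecule can move the number a long way.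

The step from compound 1 to compound 4 `O=C(CN1CCN(c2nnc(Cc3ccccc3)c3ccccc23)CC1)Nc1c(F)cccc1F` is 2,6-difluorophenyl in place of 2,4-dimethylphenyl on an amide-type nitrogen. It points in the opposite direction to the measured step: the 2,4-dimethylphenyl group that made compound 3 weaker than compound 2 is removed, and a fluorine-bearing phenyl enters. Among the compounds with values here, on that basis a lower number than the one for compound 3 is expected for compound 4, but the step in this assay from compound 2 to compound 3 involved a different aryl group and a different core substituent, so the size of the effect is uncertain. Compound 4 is expected to give an estimated 12000 nM in this assay, within a range from 2500 nM to 60000 nM.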

Compound 4, half-maximal inhibitory concentration: 84500 nM
Beside the measured number, compound 4's estimate is 7.0-fold (0.85 log units) below it, and the stated range ends below it.
By their numbers in this assay, from the lowest: compound 2; then compounds 3 and 4 (each within the scatter of the next).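

In this assay, going by these compounds alone, compound 1 gives "not active" (no number reported) and compound 4 gives 84500 nM so no step from compound 1 to compound 4 can be read. The compounds shown leave open how far the 2,6-difluorophenyl and 2,4-dimethylphenyl amides differ on the shared core. No supporting data bear on this result.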